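Benzylsulfanyl series: removing the chloro from the benzyl ring

The source may report more compounds than this note shows. Statements on the series, on what has been measured and on what is new or still open speak of the compounds shown alone.

In a functional assay on HeLa cells (Homo sapiens) for cytotoxicity, read by MTT assay, with a stated time of 72 h (a lower number here means a stronger inhibitor, a higher number a weaker inhibitor), compound 3 `Cc1cc(S(=O)(=O)/N=C(\N)n2nccc2-c2ccccc2)c(SCc2cccc(Cl)c2)cc1Cl` gives 10000 nM, the second highest of the three numbers measured. Compound 1 `Cc1cccc(CSc2cc(Cl)c(C)cc2S(=O)(=O)/N=C(\N)n2nccc2-c2ccccc2)c1` gives 8000 nM and compound 2 `Cc1ccc(CSc2cc(Cl)c(C)cc2S(=O)(=O)/N=C(\N)n2nc(C)cc2-c2ccccc2)cc1` gives 62000 nM; compound 3 lies within the scatter of compound 1 and beyond it from compound 2. The unmeasured compound 4 `Cc1cc(S(=O)(=O)/N=C(\N)n2nccc2-c2ccccc2)c(SCc2ccccc2)cc1Cl` differs from compound 3 by hydrogen in place of chloro on an aromatic carbon. Among the compounds with values here, the only measured step touching this benzyl ring, a 1.3-fold higher number from compound 1 to compound 3 (0.10 log units; within the scatter), stays within the scatter, so the substituent there has not moved the number so far. A step for complete loss of the chloro is not available. The expected step is no change at the digits printed from compound 3 to compound 4 (within the scatter), within the scatter. Compound 4 is estimated at 10000 nM, with a range of 5000 nM to 20000 nM.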

Compound 4, half-maximal inhibitory concentration: 5000 nM
Compound 4: the middle estimate sits 2.0-fold (0.30 log units) above what was measured; the range from low to high includes it.
By their numbers in this assay, from the lowest: compounds 4, 1 and 3 (each within the scatter of the next); then compound 2.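

Hydrogen now joins chloro and methyl at this place on the benzyl ring: in this assay the loss of chloro gives a 2.0-fold lower number from compound 3 to compound 4 (0.30 log units; within the scatter) and the loss of methyl gives a 1.6-fold lower number from compound 1 to compound 4 (0.20 log units; within the scatter) as its counterpart. The three compounds are therefore not separated by this assay, and the number does not depend on a substituent here. Nothing available explains this flat reading.

As far as these compounds go, whether an amine or a carboxylic acid at this place would stay within the scatter remains open.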